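Nitro for chlorine on a thromboxane semicarbazone series

The source may report more compounds than this note shows. Statements on the series, on what has been measured and on what is new or still open speak of the compounds shown alone.

Compound 1 `O=C(O)CC/C=C1/C[C@H]2C[C@@H](O)[C@H](/C=N/NC(=O)Nc3cccc(Cl)c3)[C@H]2C1` carries a 3-chlorophenyl group on the amide-type nitrogen of its semicarbazone, and in a functional assay on a cell-free system (plasma) for agonist activity at thromboxane A2 receptor (Homo sapiens) (a lower number here means a stronger inhibitor, a higher number a weaker inhibitor), compound 1 gives 600 nM. Compound 2 `O=C(O)CC/C=C1/C[C@H]2C[C@@H](O)[C@H](/C=N/NC(=O)Nc3ccc([N+](=O)[O-])cc3)[C@H]2C1` differs from it by 4-nitrophenyl in place of 3-chlorophenyl on an amide-type nitrogen, and in this assay compound 2 gives 20 nM. That change gave a 30-fold lower number from compound 1 to compound 2 (1.48 log units; beyond the scatter).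

Compound 3 `O=C(O)CCC/C=C1\C[C@H]2CC[C@H](/C=N/NC(=O)Nc3cccc(Cl)c3)[C@H]2C1` is built on a different core; how its core differs from that of compound 1 is not broken down here. In this assay compound 3 gives 6500 nM, the highest of the three numbers.

Compound 4 `O=C(O)CCC/C=C1\C[C@H]2CC[C@H](/C=N/NC(=O)Nc3ccc([N+](=O)[O-])cc3)[C@H]2C1` has not yet been measured. It differs from compound 3 by 4-nitrophenyl in place of 3-chlorophenyl on an amide-type nitrogen, the same change that links compound 1 to compound 2, made at the same place. Because the step of a 30-fold lower number from compound 1 to compound 2 (1.48 log units; beyond the scatter) was large, a step of similar direction is expected here, so that a 22-fold lower number from compound 3 to compound 4 (1.34 log units; beyond the scatter) is expected. Among the measured compounds shown here, the number for compound 4 in this assay is estimated at 300 nM, within a range from 80 nM to 1200 nM, resting on the one earlier instance of this change alone.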

Compound 4, half-maximal inhibitory concentration: 1700 nM
For compound 4 the middle estimate is 5.7-fold (0.75 log units) below the measured one, outside the stated range (above it).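

On the core of compound 3 the same change again lowers the number in this assay, with a 3.8-fold lower number from compound 3 to compound 4 (0.58 log units; beyond the scatter), so the direction of the step holds on both cores shown. This does not show which part of the cores sets the size of the step, and two pairs say nothing of how the change would behave on a third core. The size of the step, however, does not carry over from one core to the other, so the earlier step alone is a poor guide to the gain on a new core: the same change on two cores in this assay, a 30-fold lower number (1.48 log units; beyond the scatter) from compound 1 to compound 2 and a 3.8-fold lower number (0.58 log units; beyond the scatter) from compound 3 to compound 4, 7.8-fold (0.89 log units) apart, beyond the scatter of two such steps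

The compounds shown leave open whether the step on each core belongs to the nitro group itself or to the swap as a whole, since only these two aryl groups appear. A phenyl ring carrying a nitrile or an amine, set on both cores, would show whether the gap between the two steps persists with other groups.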